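The source may report more compounds than this note shows. Statements on the series, on what has been measured and on what is new or still open speak of the compounds shown alone.

The measured compounds:
compound 1, `O=C(CCC(=O)OCCCCCCSc1ccc([N+](=O)[O-])c2nonc12)Nc1cccc(Cl)c1`, which in an assay on isolated protein for inhibition of glutathione S-transferase Mu 2 (Homo sapiens), with a stated time of 10 min (on this read-out higher numbers stand for weaker inhibition and lower numbers for stronger inhibition), gives 1100 nM;
compound 2, `Cc1ccc(NC(=O)CCC(=O)OCCCCCCSc2ccc([N+](=O)[O-])c3nonc23)cc1`, which in this assay gives 390 nM.

Among the measured compounds shown here, of these two numbers compound 2 holds the lower one; its only neighbour is compound 1, and the step of a 2.8-fold lower number from compound 1 to compound 2 (0.45 log units; beyond the scatter) separates them. Compound 3, `COc1ccc(NC(=O)CCC(=O)OCCCCCCSc2ccc([N+](=O)[O-])c3nonc23)cc1`, differs from compound 2 by methoxy in place of methyl on an aromatic carbon. For the measured compounds named here, the single measured step, a 2.8-fold lower number from compound 1 to compound 2 (0.45 log units; beyond the scatter), also exchanged the aryl group on the amide-type nitrogen, 3-chlorophenyl for 4-methylphenyl, and was modest in size; it bears on the new change only loosely, as it altered the group and its place on the ring at once, while the move to compound 3 keeps the place and swaps one small group for another. On that basis the expected step is a 1.0-fold higher number from compound 2 to compound 3 (0.01 log units; within the scatter), with no change beyond the scatter. For compound 3 the estimate in this assay is 400 nM, with a range from 150 nM to 1100 nM.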

Compound 3, half-maximal inhibitory concentration: 130 nM
Beside the measured number, compound 3's estimate is 3.1-fold (0.49 log units) above it, and the stated range ends above it.
By their numbers in this assay, from the lowest: compound 3; then compound 2; then compound 1.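

In this assay, the swap of methyl for methoxy on an aromatic carbon, para to a large group, is not a silent one (a 3.0-fold lower number from compound 2 to compound 3 (0.48 log units; beyond the scatter)). With the place held, this position therefore responds to an exchange of one small group for another, which the earlier step could not show because it altered both the group and its place on the ring. The 4-methoxyphenyl group on the amide-type nitrogen also stands clearly apart from 3-chlorophenyl (an 8.5-fold lower number from compound 1 to compound 3 (0.93 log units; beyond the scatter)), and nothing available explains either step. Going by these compounds, whether an ethoxy group, a hydroxyl or an amine at this same place would give a lower or a higher number remains open. So does whether methoxy would act alike on another ring carbon, or with a shorter chain in place of the one all three compounds share.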